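The compounds below may be only part of what the source reports. "The series", "measured", "known", "first", "only" and "open" are said of these compounds alone.

Working notes on the series built on the shared core of compound 1 `C[C@@H](NC(=O)C1(NC(=O)c2ccc(Br)nc2)CC1)c1ccc(-n2nc(Cl)c3ccccc32)cc1F`, which gives 7.1 h in an in vivo ADME assay on the whole organism (strain Mongrel) for metabolic stability, with Canis familiaris (Canis lupus familiaris) as the target; a higher number here means that the compound lasts longer, a lower number that the compound disappears faster. Compound 2 `C[C@@H](NC(=O)C1(NC(=O)c2cncc(Cl)n2)CC1)c1ccc(-n2nc(Cl)c3ccccc32)cc1F` gives 15.1 h in this assay. Compound 3 `C[C@@H](NC(=O)C1(NC(=O)c2cncs2)CC1)c1ccc(-n2nc(Cl)c3ccccc32)cc1F` gives 4.3 h in this assay, the lowest of the three numbers: a 1.7-fold lower number from compound 1 to compound 3 (0.22 log units; within the scatter), while a 3.5-fold lower number from compound 2 to compound 3 (0.55 log units; beyond the scatter). Compound 4 `Cc1nnsc1C(=O)NC1(C(=O)N[C@H](C)c2ccc(-n3nc(Cl)c4ccccc43)cc2F)CC1` carries 4-methyl-1,2,3-thiadiazol-5-yl in place of 1,3-thiazol-5-yl on a carbonyl carbon. Going by the values given here, the steps that bear on this are the other swaps of the aromatic group on the carbonyl carbon, a 2.1-fold higher number from compound 1 to compound 2 (0.33 log units; beyond the scatter) together with the two steps to compound 3 just given; none of them covers a thiadiazole, and at most they are modest. A change in this assay of no more than that size, with no clear direction, is therefore expected, so a 1.2-fold higher number from compound 3 to compound 4 (0.07 log units; within the scatter) is the estimated step. Compound 4 is expected to give 5 h, within a range of 2.5 h to 10 h.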

Compound 4, half-life: 2.4 h
Compound 4: the middle estimate sits 2.1-fold (0.32 log units) above what was measured; measured number outside the range, below it.
By their numbers in this assay, from the lowest: compounds 4, 3 and 1 (each within the scatter of the next, the first and the last beyond it); then compound 2.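

In this assay, a 1.8-fold lower number from compound 3 to compound 4 (0.25 log units; within the scatter) stays within the scatter, so 4-methyl-1,2,3-thiadiazol-5-yl and 1,3-thiazol-5-yl are not told apart on this carbonyl carbon. Going by these compounds alone, the other two groups do separate from 4-methyl-1,2,3-thiadiazol-5-yl, with a 3.0-fold lower number from compound 1 to compound 4 (0.47 log units; beyond the scatter) for 6-bromopyridin-3-yl and a 6.3-fold lower number from compound 2 to compound 4 (0.80 log units; beyond the scatter) for 6-chloropyrazin-2-yl, the latter the widest step at this position so far. No measurement at hand accounts for these steps.

Going by these compounds, the methyl group and the extra ring nitrogen enter together, so their separate contributions stay open. Also open, on these data alone, is how an aliphatic amine or a carboxylic acid would behave at this position.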